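The source may hold more compounds than are shown below. What is called first, only, known or untested is meant among the compounds shown, and "the series" means these compounds.

Compound 1, `COc1ccc(Cl)cc1-n1ncc(-c2nnc(-c3cccc(F)c3)o2)c1C`, in a physicochemical assay for lipophilicity, using the shake flask method, measured as octanol-water partition; a higher number here means a more lipophilic compound, a lower number a more polar compound: 4.28
Compound 2, `COc1ccc(Cl)cc1-n1ncc(-c2nnc(-c3ccc(F)cc3)o2)c1C`, in this assay: 4.26
Compound 3, `COc1ccc(Cl)cc1-n1ncc(-c2nnc(-c3ccc(Cl)c(Cl)c3)o2)c1C`, in this assay: 5.57

Compound 2 has the lowest number of the three, but its gap to compound 1, a number 0.02 log units lower from compound 1 to compound 2 (within the scatter), lies within the scatter, so the two cannot be told apart; only compound 3 stands clearly apart, with a number 1.31 log units higher from compound 2 to compound 3 (beyond the scatter). Compound 4, `COc1ccc(Cl)cc1-n1ncc(-c2nnc(-c3ccc(C)c(Br)c3)o2)c1C`, differs from compound 2 in one place: 3-bromo-4-methylphenyl in place of 4-fluorophenyl on an aromatic carbon. The measured steps that bear on this are a number 1.31 log units higher from compound 2 to compound 3 (beyond the scatter) and a number 1.29 log units higher from compound 1 to compound 3 (beyond the scatter), both large and upward, each exchanging a single fluorine on this ring for two larger groups. Since compound 4 likewise carries two larger groups on this ring, a large upward step is expected, a number 1.24 log units higher from compound 2 to compound 4 (beyond the scatter), because of a number 1.31 log units higher from compound 2 to compound 3 (beyond the scatter). Compound 4 is estimated at 5.5, within 5.1 to 5.9.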

Compound 4, partition coefficient: 5.19
Estimate against measurement, compound 4: 0.31 log units above, and the stated range covers the measured number.
By their numbers in this assay, from the lowest: compounds 2 and 1 (each within the scatter of the next); then compound 4; then compound 3.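

Putting 3-bromo-4-methylphenyl on this ring shows that two larger groups need not lift the number in this assay as far as the 3,4-dichlorophenyl group did: the result is a number 0.93 log units higher from compound 2 to compound 4 (beyond the scatter) and a number 0.91 log units higher from compound 1 to compound 4 (beyond the scatter) and both steps are modest. Which two groups sit on the ring therefore counts, as a number 0.38 log units lower from compound 3 to compound 4 (beyond the scatter) shows. No measurement here gives a reason for this difference.

Going by these compounds, how the bromine and the methyl each contribute alone stays open. So does whether an amine or a carboxylic acid on this ring would bring the number below that of compound 2.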